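One Added Fluorine on Compound 1

This account rests on a few compounds, and the source may have more. Where it says the series, first, only, none or still open, it means among the compounds named here.

In a functional assay on HepG2 cells (Homo sapiens) for antiproliferative activity, read by MTT assay, with a stated time of 72 h (a higher number here means a weaker inhibitor, a lower number a stronger inhibitor), compound 1 `O=C1COc2ccc(-c3cccc(NS(=O)(=O)c4ccc(F)cc4)c3)cc2N1c1ccccc1` gives 30300 nM as its half-maximal inhibitory concentration, compound 2 `Cc1ccc(N2C(=O)COc3ccc(-c4cnc(Cl)c(NS(=O)(=O)c5ccc(F)cc5)c4)cc32)cc1` gives 39600 nM and compound 3 `O=C1COc2ccc(-c3cnc4ccccc4c3)cc2N1` gives 26300 nM on the same read-out. All three numbers lie within the usual scatter of one another, so compound 1 cannot be told apart from the other two, although their structures differ widely.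

Compound 4 `O=C1COc2ccc(-c3cccc(NS(=O)(=O)c4ccc(F)cc4)c3)cc2N1c1ccc(F)cc1` differs from compound 1 by a single swap of phenyl to 4-fluorophenyl (fluoro in place of hydrogen on an aromatic carbon), that is, fluoro in place of hydrogen on an aromatic carbon, para to a large group. Among the compounds with values here, no measured pair here isolates such a change, so the data give no direct guide to its size. Compound 2 at 39600 nM and compound 3 at 26300 nM remain within the scatter of compound 1 despite much larger structural differences, so no step beyond the scatter is expected in this assay for this small swap. The estimated step is a 1.1-fold lower number from compound 1 to compound 4 (0.03 log units; within the scatter) and carries no firm direction. For compound 4 the expected value is 28000 nM (estimated range 14000 nM to 55000 nM).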

Compound 4, half-maximal inhibitory concentration: > 40000 nM
Compound 4: only a limit was reported; the forecaster's own chance of this, stated with the estimate: 10%; middle value at least 1.4-fold (0.15 log units) away from the limit.
By their numbers in this assay, from the lowest: compounds 3, 1 and 2 (each within the scatter of the next). At a limit, above all of these: compound 4.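

Within the data shown here, the swap of phenyl to 4-fluorophenyl is the first change in one place that can be read in this assay, and it gives an at least 1.3-fold higher number from compound 1 to compound 4 (0.12 log units; that floor lies within the scatter). Fluoro in place of hydrogen on this aromatic carbon, para to a large group, therefore brought no lower number, although the floor of this step does not by itself establish a real rise. The reading for compound 4 is a limit of the assay, not a number: the limit of > 40000 nM in this assay, at which 1 of the 4 values shown sits.

From the compounds shown here alone, the true value of compound 4 remains unknown, so the size of this step stays open. Also open, going by these compounds, is how a different group at this same place, such as an amine or a carboxylic acid, would read in this assay.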